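Larger side chain on the amino acid of compound 1

This account rests on a few compounds, and the source may have more. Where it says the series, first, only, none or still open, it means among the compounds named here.

Compound 1 `C[C@H](NC(=O)CN(c1nc(Cl)nc2[nH]cnc12)C1CC1)C(=O)O` gives 48.1% in a functional assay on the whole organism (Tail, strain ICR) with Mus musculus as the target, in the tail flick test, with a stated time of 30 min, at a dose of 25 umol/kg by the oral route (on this read-out lower numbers stand for a weaker effect and higher numbers for a stronger effect at the one dose given), the highest of the three measured numbers. Compound 2 `C[C@H](NC(=O)CN(c1nc(Cl)nc2[nH]cnc12)C1CC1)C(=O)OCc1ccccc1` gives 41.2%; the step of a number 6.9 percentage points lower from compound 1 to compound 2 (within the scatter) lies within the scatter. Compound 3 `CC(C)C[C@H](NC(=O)CN(c1ncnc2c1ncn2C1CCCCO1)C1CC1)C(=O)OCc1ccccc1` gives 26.2%, differing from compound 2 in several places at once, so no single change accounts for that gap. Compound 4 `CC[C@H](C)[C@H](NC(=O)CN(c1nc(Cl)nc2[nH]cnc12)C1CC1)C(=O)O` carries the change (sec-butyl in place of methyl on a saturated chain carbon bound to an amide-type nitrogen and a carbonyl carbon). For the measured compounds named here, no measured step alters this position, so nothing directly bears on it. Given that compound 3, which carries a larger chain there among other changes, shows the lowest number, a small drop is expected for compound 4, as a number 10.1 percentage points lower from compound 1 to compound 4 (beyond the scatter). Compound 4 is therefore estimated at 38%, within 20% to 55%.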

Compound 4, a percentage reported as activity, at one dose (the size of the read-out at that dose, not a potency): 30.3%
Compound 4: middle estimate off by 7.7 percentage points, on the high side, within the range that was stated.
By their numbers in this assay, from the lowest: compounds 3 and 4 (each within the scatter of the next); then compounds 2 and 1 (each within the scatter of the next).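

In this assay the change to sec-butyl on a saturated chain carbon bound to an amide-type nitrogen and a carbonyl carbon gives a number 17.8 percentage points lower from compound 1 to compound 4 (beyond the scatter) and so shows that this position responds to a larger chain. The earlier compounds shown here could not show this: compound 3 carries a larger chain there only alongside other changes. Nothing measured here explains the drop. As far as these compounds go, it remains open whether an isopropyl chain, a longer straight chain or a chain ending in an amine would give a similar number at this position.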